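Swapping phenyl for a tert-butyl thiazole

The source may report more compounds than this note shows. Statements on the series, on what has been measured and on what is new or still open speak of the compounds shown alone.

Measured so far in a physicochemical assay for lipophilicity, using the shake flask method, in phosphate buffer, measured as octanol-water partition, with a stated time of 1 h, at pH 7.4; on this read-out lower numbers stand for lower lipophilicity and higher numbers for higher lipophilicity
Compound 1 `CCNC(=O)Nc1cc(-c2nc(C(F)(F)F)cs2)c(-c2nc3cccc(C(=O)O)c3s2)cn1` gives 0.73
Compound 2 `CCNC(=O)Nc1cc(-c2ccccc2)c(-c2cncc(C(=O)O)c2)cn1` gives -0.31
Compound 3 `CCNC(=O)Nc1cc(-c2nc(C(F)(F)F)cs2)c(-c2cncc(-c3c(C)noc3C)c2)cn1` gives 3.5

Compound 2 stands lowest of these three: at -0.31 it lies beyond the scatter under both others, with compound 1 the nearer and compound 3 the further away. Among the measured compounds shown here, compound 4 `CCNC(=O)Nc1cc(-c2nc(C(C)(C)C)cs2)c(-c2cncc(C(=O)O)c2)cn1` differs from compound 2 in one place, with 4-(tert-butyl)-1,3-thiazol-2-yl in place of phenyl on an aromatic carbon as the only change. For the measured compounds named here, no measured pair shows this swap alone. Compound 1 also pairs a substituted thiazole with a carboxy group, and its 0.73 is the closest guide. A rise beyond the scatter is expected in this assay as an estimated a number 1.21 log units higher from compound 2 to compound 4 (beyond the scatter) for this swap. The estimate for compound 4 is 0.9 with an expected range from 0.2 to 1.6 on this scale.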

Compound 4, distribution coefficient: 0.12
The estimate for compound 4 lay 0.78 log units above the measured number, outside the stated range (below it).
By their numbers in this assay, from the lowest: compound 2; then compound 4; then compound 1; then compound 3.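

In this assay, among the compounds shown here, 4-(tert-butyl)-1,3-thiazol-2-yl in place of phenyl gives a modest rise, a number 0.43 log units higher from compound 2 to compound 4 (beyond the scatter), the first reading of this swap alone. At this position, opposite the ring nitrogen, and with the 5-carboxypyridin-3-yl group unchanged, adding heavy atoms, including a nitrogen and a sulfur, moves the number only slightly. Still open, going by these compounds, is how the number would move with a morpholine on that same aromatic carbon, or with a methyl ester in place of the carboxy group. No measurement at hand explains the size of this step.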